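Long-chain amides: from compound 2 to compound 3

A few compounds are considered here, and "the series" means these few. Any claim that something is new, unique, unknown or untested is made for them only; others in the source may bear on it.

Compound 1 `CCCCCCCCCCCCCCCNC(=O)[C@@H]1CSC(c2ccc(NC(C)=O)cc2)N1`: 1000 nM
Compound 2 `CCCCCCCCCCCCCCCCCNC(=O)[C@@H]1CSC(c2ccc(NC(C)=O)cc2)N1`: 2400 nM

In a functional assay on WM164 cells (Homo sapiens) for antiproliferative activity, read by sulforhodamine B assay, with a stated time of 48 h (on this read-out higher numbers stand for weaker inhibition and lower numbers for stronger inhibition), compound 2, at 2400 nM, holds the higher of the two numbers. Compound 3 `CCCCCCCCC/C=C\CCCCCCCNC(=O)[C@@H]1CSC(c2ccc(NC(C)=O)cc2)N1` differs from it by a group of 11 heavy atoms (11 carbon; no ring) in place of a group of 10 heavy atoms (10 carbon; no ring), on a saturated chain carbon, seven bonds along the chain from an amide-type nitrogen, and the entering group contains a double bond. Among the compounds with values here, one measured step bears on this change: a 2.4-fold higher number from compound 1 to compound 2 (0.38 log units; beyond the scatter). Within the data shown here, it involves chain length only, and no measured compound carries a double bond. A small further rise in this assay is therefore expected, with an estimated size of a 1.2-fold higher number from compound 2 to compound 3 (0.07 log units; within the scatter). Compound 3 is expected at 2800 nM, within an estimated range of 1100 nM to 6500 nM.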

Compound 3, half-maximal inhibitory concentration: 1000 nM
Compound 3: the middle estimate sits 2.8-fold (0.45 log units) above what was measured; the measured number lies below the stated range.
By their numbers in this assay, from the lowest: compounds 1 and 3 (each within the scatter of the next); then compound 2.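

In this assay, the longer chain with a double bond does not continue the rise seen with chain length in the saturated amides: the number drops back (a 2.4-fold lower number from compound 2 to compound 3 (0.38 log units; beyond the scatter)). Compound 3 reads the same as compound 1 (no change at the digits printed from compound 1 to compound 3 (within the scatter)), so at this place chain length alone does not set the number. No evidence on the cause of this difference is at hand. A saturated chain of the same length as in compound 3 would separate the double bond from the added carbon. As far as these compounds go, how a longer chain or a carboxylic acid would read here remains open.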